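The source may hold more compounds than are shown below. What is called first, only, known or untested is meant among the compounds shown, and "the series" means these compounds.

In an ADME assay on microsomes from liver (Mus musculus) for metabolic stability (on this read-out lower numbers stand for slow clearance and higher numbers for fast clearance), compound 1 `O=C(CCCN1CCCCCC1)Nc1cnc(-c2ccc(F)cc2F)s1` gives 24 mL.min-1.g-1. For the measured compounds named here, compound 2 `O=C(CCCN1CCCCC1)Nc1cnc(-c2ccc(F)cc2)s1` gives 14 mL.min-1.g-1, and these two numbers lie within the usual scatter of each other, so compound 1 stands level with the only other measured compound. Compound 3 `O=C(CCCN1CCCCCC1)Nc1cnc(-c2ccc(F)c(F)c2)s1` has the same atoms as compound 1, joined differently: 3,4-difluorophenyl in place of 2,4-difluorophenyl on an aromatic carbon. Going by the values given here, no measured pair of compounds shows this change alone, so nothing beyond the scatter is expected in this assay. The expected step of a 1.1-fold lower number from compound 1 to compound 3 (0.06 log units; within the scatter) stays small. For compound 3 the estimated value is 21 mL.min-1.g-1, with a range of 10 mL.min-1.g-1 to 44 mL.min-1.g-1.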

Compound 3, intrinsic clearance in microsomes in the Mus musculus assay: 10 mL.min-1.g-1
Compound 3: middle estimate off by 2.1-fold (0.32 log units), on the high side, and the stated range covers the measured number.
By their numbers in the Mus musculus assay, from the lowest: compounds 3, 2 and 1 (each within the scatter of the next, the first and the last beyond it).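

In the Mus musculus assay, compound 1 gives 24 mL.min-1.g-1 and compound 3 gives 10 mL.min-1.g-1; putting 3,4-difluorophenyl in place of 2,4-difluorophenyl, with the same atoms joined differently, gives a 2.4-fold lower number from compound 1 to compound 3 (0.38 log units; beyond the scatter). For the compounds shown here, this is the first change here that can be read on its own, and it shows that clearance at this position can depend on how the two fluorines are arranged on the ring, though the step is modest. In a physicochemical assay for solubility, measured as kinetic solubility (on this read-out lower numbers stand for lower solubility and higher numbers for higher solubility), compound 1 gives > 97 ug/mL, which is a limit of the assay. In the physicochemical assay compound 3 gives > 94 ug/mL, which is also a limit of the assay. The step between these two limits cannot be read.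

Still open, as far as these compounds go, is whether 3,4-dichlorophenyl at the same place would give a number close to that of compound 3. From the compounds shown here alone, whether the step holds with another amine on the chain also remains unknown.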